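The compounds below may be only part of what the source reports. "The series", "measured", "known", "first", "only" and "open" are said of these compounds alone.

In a functional assay on LOX IMVI cells (Homo sapiens) for cytotoxicity, read by sulforhodamine B assay, with a stated time of 48 h, tested at 0.01 uM (a higher number here means a weaker effect of the compound at the concentration tested, a lower number a stronger effect), the three measured compounds give these values:

compound 1, `COc1cc(-c2cc(/C=C/C(=O)c3ccc(N)cc3)[nH]n2)cc(OC)c1OC`: 98%
compound 2, `COc1ccc(-c2cc(/C=C/C(=O)c3ccc(N)cc3)[nH]n2)cc1OC`: 100%
compound 3, `COc1cc(C(=O)/C=C/c2cc(-c3cc(OC)c(OC)c(OC)c3)n[nH]2)cc(OC)c1OC`: 102%

Compound 1 and compound 2 differ by hydrogen in place of methoxy on an aromatic carbon, and this gave a number 2 percentage points higher from compound 1 to compound 2 (within the scatter). Compound 3 carries a different core; the difference between the two cores is not broken down here, and its value sits within the scatter of the other two. Compound 4, `COc1ccc(-c2cc(/C=C/C(=O)c3cc(OC)c(OC)c(OC)c3)[nH]n2)cc1OC`, is compound 3 after the same change, (hydrogen in place of methoxy on an aromatic carbon), made at a place described in the same words as in the first pair. Because the first pair showed a number 2 percentage points higher from compound 1 to compound 2 (within the scatter), compound 4 is expected to show a number 2 percentage points lower from compound 3 to compound 4 (within the scatter). Compound 4 is therefore estimated at 100% in this assay, with a range from 92% to 108% expected.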

Compound 4, a percentage reported as activity, at one concentration (the size of the read-out at that concentration, not a potency): 96%
For compound 4 the middle estimate is 4 percentage points above the measured one; measured number inside the range.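

In this assay, replacing methoxy with hydrogen on the second core gave a number 6 percentage points lower from compound 3 to compound 4 (within the scatter). Set beside the earlier step, the two results do not separate: the same change on two cores in this assay, a number 2 percentage points higher (within the scatter) from compound 1 to compound 2 and a number 6 percentage points lower (within the scatter) from compound 3 to compound 4, 8 percentage points apart, within the scatter of two such steps. The change therefore carries from one core to the other without a detectable difference here, but neither step stands out from the scatter, so this shows neither a real effect of the change on either core nor that the two cores would respond alike where a step is large enough to read.

The compounds shown leave open whether another group at this place, such as a hydroxyl or a chlorine, would give a step beyond the scatter. They also leave open how this change behaves at other concentrations.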